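The compounds below may be only part of what the source reports. "The series", "measured", "known", "first", "only" and "open" are said of these compounds alone.

Compound 1, `O=C(O)/C=C/c1ccncc1-c1ccc2cc[nH]c2c1`, gives in a functional assay on A549 cells (Homo sapiens) for inhibition, read by sulforhodamine B assay, with a stated time of 72 h (a lower number here means a stronger inhibitor of growth, a higher number a weaker inhibitor of growth), only a limit of the assay, > 10000 nM. Compound 2, `NC(=O)/C=C/c1ccncc1-c1ccc2ccccc2c1`, gives in this assay likewise only a limit of the assay, > 10000 nM. Compound 2 thus stands at the edge of what the numbers show, where (the limit of > 10000 nM in this assay, at which 2 of the 2 values shown sit), and no number of its own is known for it; of compound 1 and compound 2 together the data show only that both sit at that limit. Compound 3, `COC(=O)/C=C/c1ccncc1-c1ccc2ccccc2c1`, is not yet measured in this assay. It differs from compound 2 by methoxy in place of amino on a carbonyl carbon. Among the measured compounds shown here, no step between measured compounds is available to size this change, so the step that the limit leaves unreadable from compound 2 to compound 3 is expected to be none beyond the scatter, in no clear direction. Because compound 2 shows only > 10000 nM, compound 3 is expected to give about 12000 nM in this assay, between 4000 nM and 40000 nM.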

Compound 3, concentration for 50% growth inhibition: 760 nM
The estimate for compound 3 lay 16-fold (1.20 log units) above the measured number; measured number below the stated range.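

At this carbonyl carbon the group matters: in this assay, methoxy in place of amino gives an at least 13-fold lower number from compound 2 to compound 3 (1.11 log units; beyond the scatter). Compound 3, at 760 nM, is the first compound shown with a number of its own. The earlier limits therefore do not hold for every compound in this set. The step is still only a bound, since its starting point is a limit and not a number: the limit of > 10000 nM in this assay, at which 2 of the 3 values shown sit.

As far as these compounds go, whether the difference belongs to the methoxy itself or to the loss of the amino stays open, as does how an ethoxy or a methylamino group on the same carbonyl carbon would read. Also open, from the compounds shown here alone, is whether a methyl ester would behave in the same way on the core of compound 1, which carries a carboxylic acid.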